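Aryl for Alkyne: Expected Clearance of Compound 4

A few compounds are considered here, and "the series" means these few. Any claim that something is new, unique, unknown or untested is made for them only; others in the source may bear on it.

Compound 1 `Nc1ccc(S(=O)(=O)N2CCN(c3ncc(C(O)(C(F)(F)F)C(F)(F)F)cc3C#CCO)CC2)cn1` gives < 14 mL.min-1.g-1 in an ADME assay (liver) for metabolic stability, with Liver microsome (Homo sapiens) as the target, using microsomes and NADPH, with a stated time of 30 min, tested at 1 uM (a higher number here means faster removal of the compound, a lower number slower removal), a limit of the assay.
Compound 2 `COCC#Cc1cc(C(O)(C(F)(F)F)C(F)(F)F)cnc1N1CCN(S(=O)(=O)c2ccc(N)nc2)CC1` gives 15 mL.min-1.g-1.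
Compound 3 `CS(=O)(=O)Nc1cccc(-c2cc(C(O)(C(F)(F)F)C(F)(F)F)cnc2N2CCN(S(=O)(=O)c3ccc(N)nc3)CC2)c1` gives 40 mL.min-1.g-1.

Among the numbers shown, compound 2 has the lowest. Compound 4 `Nc1ccc(S(=O)(=O)N2CCN(c3ncc(C(O)(C(F)(F)F)C(F)(F)F)cc3-c3ccncc3)CC2)cn1` differs from it by one change: pyridin-4-yl in place of 3-methoxyprop-1-yn-1-yl on an aromatic carbon. For the measured compounds named here, two measured steps bear on this, both swapping an alkyne-bearing side chain for a six-membered aromatic ring on the same carbon of the shared core: a 2.7-fold higher number from compound 2 to compound 3 (0.43 log units; beyond the scatter) and an at least 2.8-fold higher number from compound 1 to compound 3 (0.45 log units; beyond the scatter). Both point the same way, toward a modest rise in this assay. A similar rise is therefore expected here, with a 2.0-fold higher number from compound 2 to compound 4 (0.30 log units; within the scatter). Compound 4 is thus estimated at 30 mL.min-1.g-1, between 14 mL.min-1.g-1 and 65 mL.min-1.g-1.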

Compound 4, intrinsic clearance in microsomes: 15 mL.min-1.g-1
Compound 4: the middle estimate sits 2.0-fold (0.30 log units) above what was measured; the measured number falls inside the stated range.
By their numbers in this assay, from the lowest: compounds 2 and 4 (each within the scatter of the next); then compound 3. At a limit, below all of these: compound 1.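

At this aromatic carbon, ortho to a large group, a six-membered aromatic ring need not raise the number in this assay: pyridin-4-yl in place of 3-methoxyprop-1-yn-1-yl gives no change at the digits printed from compound 2 to compound 4 (within the scatter). The rise seen with 3-(methanesulfonamido)phenyl is thus not shared by every aromatic ring here, as pyridin-4-yl in its place shows a 2.7-fold lower number from compound 3 to compound 4 (0.43 log units; beyond the scatter). The step with 3-hydroxyprop-1-yn-1-yl leaving reads only as a floor, an at least 1.0-fold higher number from compound 1 to compound 4 (0.02 log units; that floor lies within the scatter), and rests on a limit of the assay: the limit of < 14 mL.min-1.g-1 in this assay, at which 1 of the 4 values shown sits.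

The compounds shown leave open whether the number stays as low with pyridin-3-yl or an unsubstituted phenyl at this carbon. They also leave open which part of 3-(methanesulfonamido)phenyl goes with its higher number.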